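Swapping the Amide Aryl Group in a Cytotoxicity Series

A few compounds are considered here, and "the series" means these few. Any claim that something is new, unique, unknown or untested is made for them only; others in the source may bear on it.

Compound 1: `COc1ccc(CNC(=O)CSc2nc3ccc(NC(=O)c4ccc(Cl)cc4)cc3s2)cc1` — 19200 nM
Compound 2: `CNC(=O)CSc1nc2ccc(NC(=O)c3ccc(Cl)cc3)cc2s1` — 29400 nM

In a functional assay on MCF7 cells (Homo sapiens) for cytotoxicity, read by MTT assay, with a stated time of 48 h (on this read-out lower numbers stand for stronger inhibition and higher numbers for weaker inhibition), compound 1 stands at the lower of the two numbers shown, though the step of a 1.5-fold higher number from compound 1 to compound 2 (0.19 log units; within the scatter) lies within the scatter. Compound 3, `COc1ccc(CNC(=O)CSc2nc3ccc(NC(=O)c4ccccc4OC)cc3s2)cc1`, differs from compound 1 by 2-methoxyphenyl in place of 4-chlorophenyl on a carbonyl carbon. For the measured compounds named here, no measured step touches this end of the shared core; the only step available alters the other amide end and stayed within the scatter. For compound 3 the number is therefore expected to remain near that of compound 1, with a step of a 1.3-fold higher number from compound 1 to compound 3 (0.11 log units; within the scatter) not expected to exceed the scatter. The estimate for compound 3 is 25000 nM, ranging from 8000 nM to 80000 nM.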

Compound 3, half-maximal inhibitory concentration: 9300 nM
Compound 3: middle estimate off by 2.7-fold (0.43 log units), on the high side, and the stated range covers the measured number.
By their numbers in this assay, from the lowest: compound 3; then compounds 1 and 2 (each within the scatter of the next).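

For the compounds shown here, the carbonyl end of the shared core responds in this assay: with 2-methoxyphenyl in place of 4-chlorophenyl, the result is a 2.1-fold lower number from compound 1 to compound 3 (0.31 log units; beyond the scatter) and is the only step here beyond the scatter. The change at the other amide end stayed within the scatter. No available evidence explains the step. Since the chlorine left as the methoxy entered, the compounds shown do not separate the two changes. On these data alone, how a plain phenyl or a pyridine ring on that carbonyl carbon would read remains open, as does whether the step carries over to compound 2.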